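Carbonyl substituent changes on the shared core

A few compounds are considered here, and "the series" means these few. Any claim that something is new, unique, unknown or untested is made for them only; others in the source may bear on it.

Going by the values given here, compound 2 `CCN(CC)C(=O)c1sc(-c2ccc(Cl)cc2)nc1C(Br)Br` gives 63500 nM in an ADME assay on BHK15 cells (Mesocricetus auratus) for inhibition, read by XTT assay, with a stated time of 36 h (a lower number here means a stronger inhibitor of growth, a higher number a weaker inhibitor of growth), the second highest of the three numbers measured so far. Compound 1 `CN(C)C(=O)c1sc(-c2ccc(Cl)cc2)nc1C(Br)Br` gives 163000 nM and compound 3 `C=CCNC(=O)c1sc(-c2ccc(Cl)cc2)nc1C(Br)Br` gives 40800 nM in this assay. The step of a 2.6-fold lower number from compound 1 to compound 2 (0.41 log units; beyond the scatter) and the step of a 4.0-fold lower number from compound 1 to compound 3 (0.60 log units; beyond the scatter) are both modest, while the step of a 1.6-fold lower number from compound 2 to compound 3 (0.19 log units; within the scatter) lies within the scatter. Compound 4 `CC(=O)c1sc(-c2ccc(Cl)cc2)nc1C(Br)Br` differs from compound 2 by methyl in place of diethylamino on a carbonyl carbon. All three measured steps alter the group on the same carbonyl carbon, and none is more than modest, but none matches this particular change, so its direction is open. A modest step of a 1.2-fold lower number from compound 2 to compound 4 (0.06 log units; within the scatter) in this assay is therefore expected, in either direction. Compound 4 is estimated at 55000 nM, within a range of 15000 nM to 200000 nM.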

Compound 4, concentration for 50% growth inhibition: 83500 nM
Compound 4: middle estimate off by 1.5-fold (0.18 log units), on the low side; low and high end bracket the measured number.
By their numbers in this assay, from the lowest: compounds 3, 2, 4 and 1 (each within the scatter of the next, the first and the last beyond it).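

In this assay, methyl in place of diethylamino gives a 1.3-fold higher number from compound 2 to compound 4 (0.12 log units; within the scatter) and methyl in place of dimethylamino gives a 2.0-fold lower number from compound 1 to compound 4 (0.29 log units; within the scatter) and so, on this carbonyl carbon, a nitrogen substituent is not needed for a number in this range. Only allylamino stands apart from methyl, with a 2.0-fold higher number from compound 3 to compound 4 (0.31 log units; beyond the scatter) as a modest step. Nothing available here accounts for these steps.

Still open, from the compounds shown here alone, is whether a carboxylic acid, a cyclic amine such as morpholine or a longer chain on this carbonyl carbon would move the number further than these groups do.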